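Swapping the Anilide of Compound 2 for a Piperidine Amide

A few compounds are considered here, and "the series" means these few. Any claim that something is new, unique, unknown or untested is made for them only; others in the source may bear on it.

Measured so far:
compound 1 `N#C/C(=C\c1cc(O)c(O)c([N+](=O)[O-])c1)C(=O)N(c1ccccc1)c1ccccc1`: 104 ug/mL
compound 2 `Cc1cccc(NC(=O)/C(C#N)=C/c2cc(O)c(O)c([N+](=O)[O-])c2)c1`: 12.5 ug/mL
compound 3 `COc1c(O)ccc(/C=C(\C#N)C(=O)Nc2cccc(Cl)c2)c1[N+](=O)[O-]`: > 100 ug/mL, a limit of the assay rather than a number

All three share one core, and they are compared in a functional assay on KB cells (Homo sapiens) for antiproliferative activity, read by MTT assay; a lower number here means a stronger inhibitor, a higher number a weaker inhibitor. Compound 2 has the lowest of the two numbers; its nearest neighbour, compound 1, sits at a higher number by a margin beyond the usual scatter. For compound 3 the assay gives only a limit (the limit of > 100 ug/mL in this assay, at which 1 of the 3 values shown sits).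

Compound 4 `N#C/C(=C\c1cc(O)c(O)c([N+](=O)[O-])c1)C(=O)N1CCCCC1` differs from compound 2 in one place: piperidin-1-yl in place of (3-methylphenyl)amino on a carbonyl carbon. Among the measured compounds shown here, no measured pair shows exactly this change, so the expectation rests on what the three numbers show. Compound 1, the other compound without a hydrogen on its amide nitrogen, gives a higher number than compound 2, and compound 4 likewise loses that hydrogen. A step toward a higher number, of moderate size and beyond the scatter, is therefore expected from compound 2 to compound 4: a 3.2-fold higher number from compound 2 to compound 4 (0.51 log units; beyond the scatter). Compound 4 is estimated at 40 ug/mL, within a range from 12 ug/mL to 100 ug/mL.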

Compound 4, half-maximal inhibitory concentration: > 100 ug/mL
Compound 4 ended at the assay's limit; the forecaster's own chance of this, stated with the estimate: 25%; at least 2.5-fold (0.39 log units) between middle value and limit.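

Among the compounds shown here, at this position on a carbonyl carbon, putting piperidin-1-yl in place of (3-methylphenyl)amino in this assay gives an at least 8.0-fold higher number from compound 2 to compound 4 (0.90 log units; beyond the scatter), so this is the first direct comparison showing that the group here strongly affects the result. A six-membered ring alone is therefore not enough to keep compound 4 as strong as compound 2. The value of compound 4, > 100 ug/mL, is a limit of the assay and not a number, so the true size of the step remains unknown: the limit of > 100 ug/mL in this assay, at which 2 of the 4 values shown sit.

The change removes the aromatic ring and the amide hydrogen together, and these compounds cannot show which loss matters. Going by these compounds, a cyclohexylamino group, which pairs a non-aromatic ring with a retained amide hydrogen, would separate the two, and its effect at this position remains open.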